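This account rests on a few compounds, and the source may have more. Where it says the series, first, only, none or still open, it means among the compounds named here.

Compound 1, with the structure `Brc1c(Nc2ncc[nH]2)ccc2nccnc12`, carries a bromo group on its fused core. In an assay on CHO cells for displacement of a labelled ligand from Alpha-2C adrenergic receptor (Homo sapiens) (on this read-out lower numbers stand for stronger inhibition and higher numbers for weaker inhibition), compound 1 gives > 10000 nM, and this figure is a limit of the assay, not a measured number. Among the two values shown, compound 1 sits at the limit of > 10000 nM in this assay, at which 1 of the 2 values shown sits, so its true inhibition constant is only known to lie beyond that point. Compound 2, with the structure `Clc1cccc(Cl)c1Nc1ncc[nH]1`, gives 1100 nM in this assay. Compound 3, with the structure `Cc1c(Nc2ncc[nH]2)ccc2nccnc12`, has not yet been measured; it differs from compound 1 by methyl in place of bromo on an aromatic carbon, a methyl in place of bromo on an aromatic carbon. Within the data shown here, no measured pair shows this exchange, so there is no step to lean on. Compound 1 at the limit gives little room to move, and the swap of one heavy atom for another is modest, so the expected step is a step that the limit leaves unreadable from compound 1 to compound 3, within the usual scatter. For compound 3 the expected value is 12000 nM, between 3000 nM and 40000 nM.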

Compound 3, inhibition constant: 340 nM
Compound 3: middle estimate off by 35-fold (1.55 log units), on the high side; measured number below the stated range.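

Exchanging bromo for methyl on this aromatic carbon gives an at least 29-fold lower number from compound 1 to compound 3 (1.46 log units; beyond the scatter) in this assay. This shows that the group at this one position, ortho to a group of 6 heavy atoms, can strongly change the reading on the shared core, even though one heavy atom replaces one heavy atom and the counts of hydrogen-bond donors and acceptors stay the same. The full size of the step remains unknown, since compound 1 stands at a limit of the assay: the limit of > 10000 nM in this assay, at which 1 of the 3 values shown sits.

Only two groups at this position are shown, so it remains open how an ethyl group, a methoxy group or an amine would read there, and why methyl and bromo differ so much. Compound 2 differs from both compounds in more than one place, so it adds no comparison for this position.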